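Taking the hydroxy off compound 3

The source may hold more compounds than are shown below. What is called first, only, known or untested is meant among the compounds shown, and "the series" means these compounds.

compound 1 `Cc1nc(C)c(/C=C/C(=O)/C=C/c2cccc(O)c2)nc1C` gives 4300 nM in this series
compound 2 `COc1cc(/C=C/C(=O)/C=C/c2nc(C)c(C)nc2C)ccc1O` gives 2190 nM in this series
compound 3 `COc1cccc(/C=C/C(=O)/C=C/c2nc(C)c(C)nc2C)c1O` gives 2850 nM in this series

In a functional assay on A549 cells (Homo sapiens) for antiproliferative activity, read by MTT assay, with a stated time of 72 h (a lower number here means a stronger inhibitor, a higher number a weaker inhibitor), compound 3 gives 2850 nM as a number that stands level with the other two, since its gaps to compound 1 and to compound 2 both lie within the usual scatter. No order can be read among these compounds.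

The next compound is compound 4 `COc1cccc(/C=C/C(=O)/C=C/c2nc(C)c(C)nc2C)c1` which differs from compound 3 in a single place. The change is hydrogen in place of hydroxy on an aromatic carbon and in words it is hydrogen in place of hydroxy on an aromatic carbon, ortho to a large group and ortho to a methoxy group.

For the measured compounds named here, every measured compound keeps a hydroxy, so the data hold no direct example of losing one. Their structures do vary, yet their numbers stay close together. In this assay no step beyond the scatter is therefore expected, with a slight drift toward a higher number as the likelier direction. The expected result is a 1.2-fold higher number from compound 3 to compound 4 (0.09 log units; within the scatter) and this estimate stays small. For compound 4 the estimated value is 3500 nM with an expected range from 1400 nM to 9000 nM around it.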

Compound 4, half-maximal inhibitory concentration: 3300 nM
Estimate against measurement, compound 4: 1.1-fold (0.03 log units) above; the range from low to high includes it.
By their numbers in this assay, from the lowest: compounds 2, 3, 4 and 1 (each within the scatter of the next).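

In this assay, for the compounds shown here, the step of a 1.2-fold higher number from compound 3 to compound 4 (0.06 log units; within the scatter) is the first direct example of losing a hydroxy, here from the aromatic carbon ortho to a large group and ortho to a methoxy group, and it lies within the scatter, so this hydroxy is not required for the activity seen in these cells. The two other new steps also stay within the scatter: a 1.5-fold higher number from compound 2 to compound 4 (0.18 log units; within the scatter) is again hydrogen in place of hydroxy, and a 1.3-fold lower number from compound 1 to compound 4 (0.11 log units; within the scatter) is methyl in place of hydrogen on an oxygen on an aromatic ring, so none of the three single changes separates the compounds in this assay. Nothing measured alongside these numbers accounts for this lack of separation.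

The compounds shown leave open whether a different group at this position, such as an amine, a fluorine atom or a carboxylic acid, would give a step beyond the scatter. They also leave open whether a longer chain, such as an ethoxy or butoxy group, in place of the methoxy group would do so.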